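The compounds below may be only part of what the source reports. "The series", "measured", "known", "first", "only" and "open" are said of these compounds alone.

Sulfur-bearing chain ends on a shared pyridazinone-free core? No: Three chain variants and a fourth to come

Measured compounds:
compound 1 `NC(=O)CCn1nc(-c2ccccc2)ccc1=O`: -2.8%
compound 2 `N=C(S)CCCCCn1nc(-c2ccccc2)ccc1=O`: 91.4%
compound 3 `CCOC(=O)CCn1nc(-c2ccccc2)ccc1=O`: 6.3%

The read-out is a functional assay on the whole organism (stomach) for inhibition, with Rattus norvegicus as the target, at a dose of 100 mg/kg by the intraduodenal route; on this read-out lower numbers stand for less inhibition and higher numbers for more inhibition at the one dose given (going by the name of the read-out). Compound 3 stands second highest of the three numbers; its nearest neighbour is compound 1, within the usual scatter, while compound 2 lies far above it. The step of a number 9.1 percentage points higher from compound 1 to compound 3 (within the scatter) is within the scatter, so compound 1 and compound 3 cannot be told apart on these numbers. The step of a number 94.2 percentage points higher from compound 1 to compound 2 (beyond the scatter) is large, and so is the step of a number 85.1 percentage points lower from compound 2 to compound 3 (beyond the scatter) in the other direction; in both cases the group containing 1 sulfur on the chain goes with the high number.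

Compound 4 `O=c1ccc(-c2ccccc2)nn1CCC(=S)N1CCCC1` is not yet measured. Relative to compound 3 the change is a group of 7 heavy atoms (5 carbon, 1 nitrogen, 1 sulfur; one five-membered non-aromatic ring with 1 hetero atom) in place of a group of 5 heavy atoms (3 carbon, 2 oxygen; no ring), on a saturated chain carbon, two bonds along the chain from an aromatic nitrogen. The entering group again carries 1 sulfur and 1 nitrogen, as in compound 2, while the leaving ethoxycarbonyl is the group that went with the low number in compound 3. Among the measured compounds shown here, the steps that bear on this are the large rise from compound 1 to compound 2 and the large fall from compound 2 to compound 3. Compound 4 is therefore expected to move beyond the scatter upward, by about a number 48.7 percentage points higher from compound 3 to compound 4 (beyond the scatter). The estimate for compound 4 is 55%, with a range from 15% to 95%.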

Compound 4, a percentage reported as inhibition, in the whole organism at one dose (the size of the read-out at that dose, not a potency): 38.2%
Beside the measured number, compound 4's estimate is 16.8 percentage points above it; low and high end bracket the measured number.
By their numbers in this assay, from the lowest: compounds 1 and 3 (each within the scatter of the next); then compound 4; then compound 2.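

In this assay, the group with the five-membered non-aromatic ring, in place of ethoxycarbonyl on the saturated chain carbon, gives a number 31.9 percentage points higher from compound 3 to compound 4 (beyond the scatter), and set against the amide end of the first compound it gives a number 41 percentage points higher from compound 1 to compound 4 (beyond the scatter), so a ring-bearing sulfur group at this place stands clear of both low compounds. Holding sulfur and nitrogen does not by itself bring the highest number, however, since the change between the two sulfur-bearing groups gives a number 53.2 percentage points lower from compound 2 to compound 4 (beyond the scatter), which shows that these groups can differ widely at this place. Nothing on hand explains either gap.

The compounds shown leave open whether the sulfur itself matters, which a pyrrolidine amide with a carbonyl in place of the thiocarbonyl on the same chain would test. They also leave open how much of the gap to compound 2 belongs to chain length and how much to the chain end, which a longer chain ending in the same pyrrolidine group would help to separate.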